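A methyl leaves the ring: compound 2 to compound 4

The source may report more compounds than this note shows. Statements on the series, on what has been measured and on what is new or still open speak of the compounds shown alone.

Of the compounds shown here, three sharing one core have been measured in a physicochemical assay for lipophilicity, measured as octanol-water partition; on this read-out higher numbers stand for higher lipophilicity and lower numbers for lower lipophilicity. Compound 1 `Cc1c(NCc2nnc(COc3ccccc3)o2)c(=O)n(-c2ccccc2)n1C` gives 0.98. Compound 2 `Cc1ccc(-c2nnc(CNc3c(C)n(C)n(-c4ccccc4)c3=O)o2)cc1` gives 2.48, and compound 3 `Cc1ccccc1-c1nnc(CNc2c(C)n(C)n(-c3ccccc3)c2=O)o1` gives 2.38. Compound 2 thus stands at the upper end of these numbers, together with compound 3: the two lie within the scatter of each other a number 0.10 log units lower from compound 2 to compound 3 (within the scatter), while both sit well above compound 1 a number 1.50 log units higher from compound 1 to compound 2 (beyond the scatter) a number 1.40 log units higher from compound 1 to compound 3 (beyond the scatter).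

Compound 4 `Cc1c(NCc2nnc(-c3ccccc3)o2)c(=O)n(-c2ccccc2)n1C` differs from compound 2 in one place: hydrogen in place of methyl on an aromatic carbon. Among the measured compounds shown here, no measured step removes a methyl from this ring; the step from compound 2 to compound 3 only moves it, with no change beyond the scatter. The large measured steps concern the whole group on the aromatic carbon and do not bear directly on losing one carbon. A modest drop in this assay is therefore expected, a number 0.53 log units lower from compound 2 to compound 4 (beyond the scatter). Compound 4 is estimated at 1.95, within the range 1.55 to 2.35.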

Compound 4, partition coefficient: 2.02
Estimate against measurement, compound 4: 0.07 log units below; low and high end bracket the measured number.
By their numbers in this assay, from the lowest: compound 1; then compound 4; then compounds 3 and 2 (each within the scatter of the next).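

Going from 4-methylphenyl to phenyl gives a number 0.46 log units lower from compound 2 to compound 4 (beyond the scatter) in this assay and is the first step here that removes a carbon rather than moving it. Going from 2-methylphenyl to phenyl gives a number 0.36 log units lower from compound 3 to compound 4 (beyond the scatter) in the same read-out, so a single methyl on this ring shifts the number beyond the scatter from either of the two places shown, even though moving it between them did not. The methyl is still only part of the large gap to compound 1, since a number 1.04 log units higher from compound 1 to compound 4 (beyond the scatter) remains with no methyl present.

Nothing available explains the size of these steps. Also open, on these data alone, is how the number would respond to an ethyl group, a chlorine atom or an amine on the same aromatic carbon in place of the methyl.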